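The compounds below may be only part of what the source reports. "The series", "measured", "known", "first", "only" and "open" are said of these compounds alone.

Compound 1 `Cc1ccccc1-c1nn(-c2ccc(F)cc2F)cc1CNCCCCO` in an ADME assay on Huh-7 cells (Homo sapiens) for cytotoxicity (a higher number here means that more compound is tolerated, a lower number that less compound is tolerated), gives > 20000 nM, which is a limit of the assay rather than a number.
Compound 2 `Cc1ccccc1-c1nn(-c2ccc(F)cc2F)cc1CNC1CCN(S(C)(=O)=O)CC1` in this assay gives > 20000 nM, also a limit.
Compound 3 `COc1ccc(-n2cc(CNCCN3CCN(C)CC3)c(-c3ccccc3C)n2)cc1` in this assay gives > 20000 nM, again a limit.

Compound 3 therefore stands only at a limit, as do the other two values shown (the limit of > 20000 nM in this assay, at which 3 of the 3 values shown sit). Going by the values given here, the one measured step, a step that the two limits leave unreadable from compound 1 to compound 2, has limits at both ends and shows no readable size. Compound 4 `Cc1ccccc1-c1nn(-c2ccc(F)c(F)c2)cc1CNCCN1CCN(C)CC1` differs from compound 3 by 3,4-difluorophenyl in place of 4-methoxyphenyl on an aromatic nitrogen. Among the compounds with values here, no measured step touches this change, so no direction beyond the scatter can be argued from the numbers at hand. The step that the limit leaves unreadable from compound 3 to compound 4 is expected to be nil, with compound 4 most likely again sitting at the limit. Compound 4 is estimated at 30000 nM, with a range from 12000 nM to 80000 nM.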

Compound 4, half-maximal cytotoxic concentration: > 20000 nM
Compound 4 ended at the assay's limit; the forecaster's own chance of this, stated with the estimate: 80%; the middle value lies beyond the limit too.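

No step can be read from compound 3 to compound 4, because both stand at a limit of the assay rather than at a number: the limit of > 20000 nM in this assay, at which 4 of the 4 values shown sit.

The compounds shown leave open whether 3,4-difluorophenyl in place of 4-methoxyphenyl changes the result in this assay at all.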